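The compounds below may be only part of what the source reports. "The series", "measured", "known", "first", "only" and "open" are said of these compounds alone.

In a physicochemical assay for solubility, in phosphate buffer (a higher number here means a more soluble compound, a lower number a less soluble compound), compound 2 (`CO[C@H](C[C@H](CCN1CCCC(CO)C1)C(=O)NO)c1ccc(F)cc1`) gives > 5 ug/mL, which is a limit and not a number. Compound 1 (`Cc1cc(N[C@H](CCCCNCc2ccc(C(C)(C)C)cc2)C(=O)NO)cc(C)c1F`) gives > 5 ug/mL, also a limit. Compound 3 (`CO[C@H](C[C@H](CCN1CCCC(Cc2ccc(F)cc2)C1)C(=O)NO)c1ccc(F)cc1`) gives > 5 ug/mL, again a limit. The measurements so far therefore come down to the limit of > 5 ug/mL in this assay, at which 3 of the 3 values shown sit, and compound 2 cannot be placed more exactly among them.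

Compound 4 (`CO[C@H](C[C@H](CCN1CCNCC1)C(=O)NO)c1ccc(F)cc1`) differs from compound 2 in one place, on a saturated chain carbon, three bonds along the chain from a carbonyl carbon: piperazin-1-yl in place of 3-(hydroxymethyl)piperidin-1-yl on a saturated chain carbon, three bonds along the chain from a carbonyl carbon. Among the measured compounds shown here, the only measured step that bears on this change is a step that the two limits leave unreadable from compound 2 to compound 3, which offers no size to carry over to compound 4. No step beyond the scatter can therefore be expected in this assay, in either direction. The estimated step is a step that the limit leaves unreadable from compound 2 to compound 4. For compound 4 the expected value is 6 ug/mL, with an estimated range from 4 ug/mL to 12 ug/mL, and the result may well be reported again only as a limit.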

Compound 4, solubility: > 5 ug/mL
Compound 4: no number, only a limit (the forecaster's own chance of this, stated with the estimate: 85%); the middle value does not contradict the limit.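

In this assay compound 4 gives > 5 ug/mL, which is a limit and not a number. Among the compounds shown here, compound 2 also stands at a limit, and no step between compound 2 and compound 4 can be read. The compounds shown leave open how far each one's actual solubility lies past that limit.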